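A few compounds are considered here, and "the series" means these few. Any claim that something is new, unique, unknown or untested is made for them only; others in the source may bear on it.

In a functional assay on Huh-7 cells (Homo sapiens) for inhibition, read by CCK-8 assay, with a stated time of 72 h (a higher number here means a weaker inhibitor, a lower number a stronger inhibitor), compound 1 (`Cc1ccc(NS(=O)(=O)c2cccc(CCCCCCNC(=O)/C=C/c3cccnc3)c2)cc1`) gives 6.92 nM and compound 2 (`Cc1ccccc1NS(=O)(=O)c1cccc(CCCCCCNC(=O)/C=C/c2cccnc2)c1`) gives 0.525 nM while compound 3 (`Cc1cccc(NS(=O)(=O)c2cccc(CCCCCCNC(=O)/C=C/c3cccnc3)c2)c1`) gives 13.2 nM as its reading. The 3-methylphenyl and 4-methylphenyl compounds do not separate: a 1.9-fold higher number from compound 1 to compound 3 (0.28 log units; within the scatter) stays within the scatter. Compound 2 is the strongest of the three, and a 25-fold higher number from compound 2 to compound 3 (1.40 log units; beyond the scatter) lies beyond the scatter.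

Going on to compound 4 (`Cc1ccc(C)c(NS(=O)(=O)c2cccc(CCCCCCNC(=O)/C=C/c3cccnc3)c2)c1`), the change (methyl in place of hydrogen on an aromatic carbon) is methyl in place of hydrogen on an aromatic carbon, ortho to a large group and para to a methyl group, so that 3-methylphenyl becomes 2,5-dimethylphenyl. Among the compounds with values here, the steps that bear on this are the two reaching the 2-methylphenyl of compound 2, namely a 13-fold lower number from compound 1 to compound 2 (1.12 log units; beyond the scatter) and also a 25-fold higher number from compound 2 to compound 3 (1.40 log units; beyond the scatter) in reverse, both large. Within the data shown here, no measured compound carries two ring methyls, so whether that gain survives alongside the methyl of compound 3 is untested. A large step toward a lower number in this assay is therefore expected, with a reading that probably stays weaker than that of compound 2, which gives 0.525 nM. The expected step is an 8.8-fold lower number from compound 3 to compound 4 (0.94 log units; beyond the scatter) on this reasoning. Compound 4 is estimated at 1.5 nM within an expected range from 0.3 nM to 8 nM for this reading.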

Compound 4, half-maximal inhibitory concentration: 2.58 nM
Compound 4: the middle estimate sits 1.7-fold (0.24 log units) below what was measured; measured number inside the range.
By their numbers in this assay, from the lowest: compound 2; then compound 4; then compounds 1 and 3 (each within the scatter of the next).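

In this assay, methyl in place of hydrogen on the aromatic carbon ortho to a large group and para to a methyl group turns 3-methylphenyl into 2,5-dimethylphenyl and gives a real gain (a 5.1-fold lower number from compound 3 to compound 4 (0.71 log units; beyond the scatter)), so this position still responds when a second ring methyl is present. The gain is only partial, since the same 2,5-dimethylphenyl ring, seen as compound 2 with one more methyl, gives up part of the reading of the 2-methylphenyl compound (a 4.9-fold higher number from compound 2 to compound 4 (0.69 log units; beyond the scatter)), yet it stays ahead of the 4-methylphenyl compound (a 2.7-fold lower number from compound 1 to compound 4 (0.43 log units; beyond the scatter)); the two ring methyls therefore do not add up, and the single methyl of compound 2 remains the best arrangement among these four compounds. Nothing on hand accounts for these differences.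

As far as these compounds go, whether the gain belongs to methyl specifically stays open, as chloro or methoxy in place of that methyl would test it, and ethyl would show whether a larger group at the same carbon holds the reading of compound 2. A shorter or longer chain in place of the linking chain, carrying the 2-methylphenyl ring, is also an open question for this series.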